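Isopropylamino to ethyl(methyl)amino on two different cores

A few compounds are considered here, and "the series" means these few. Any claim that something is new, unique, unknown or untested is made for them only; others in the source may bear on it.

Compound 1 `CC(C)NC(=O)N1CCN(C(=S)SCc2cn(Cc3ccccc3F)nn2)CC1` and compound 2 `CCN(C)C(=O)N1CCN(C(=S)SCc2cn(Cc3ccccc3F)nn2)CC1` stand on one core; compound 3 `COc1cc(Cn2cc(CSC(=S)N3CCN(C(=O)NC(C)C)CC3)nn2)cc(OC)c1OC` and compound 4 `CCN(C)C(=O)N1CCN(C(=S)SCc2cn(Cc3cc(OC)c(OC)c(OC)c3)nn2)CC1` stand on another. The difference between the two cores is not broken down here. In a functional assay on MCF7 cells (Homo sapiens) for cytotoxicity, read by MTT assay, with a stated time of 72 h (a higher number here means a weaker inhibitor, a lower number a stronger inhibitor), compound 1 gives 1860 nM. In this assay compound 2 gives 7210 nM. The step of a 3.9-fold higher number from compound 1 to compound 2 (0.59 log units; beyond the scatter) rests on the change (ethyl(methyl)amino in place of isopropylamino on a carbonyl carbon).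

Compound 3 in this assay returns only a limit of the assay, > 128000 nM, so no number is known for it. This is the limit described as the limit of > 128000 nM in this assay, at which 1 of the 3 values shown sits.

Compound 4 carries the same change relative to compound 3, namely (ethyl(methyl)amino in place of isopropylamino on a carbonyl carbon), and the place is described in the same words for both pairs, so it is the same change, now on the second core. For the measured compounds named here, the only measured instance of the change, a 3.9-fold higher number from compound 1 to compound 2 (0.59 log units; beyond the scatter), moved the number upward, and compound 3 already sits at a limit. For compound 4 the expected step is therefore a step that the limit leaves unreadable from compound 3 to compound 4, pointing further upward or staying at the limit, with the expectation that a limit rather than a number is most likely reported. In this assay compound 4 is expected to give about 250000 nM, with a range estimated from 100000 nM to 800000 nM.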

Compound 4, half-maximal inhibitory concentration: 68500 nM
Beside the measured number, compound 4's estimate is 3.6-fold (0.56 log units) above it; measured number below the stated range.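

In this assay the change from isopropylamino to ethyl(methyl)amino on a carbonyl carbon gives an at least 1.8-fold lower number from compound 3 to compound 4 (0.27 log units; that floor lies within the scatter), and set against the step on the core of compound 1, it does not carry over to the core of compound 3 with the same direction or size: the same change on two cores in this assay, a 3.9-fold higher number (0.59 log units; beyond the scatter) from compound 1 to compound 2 and an at least 1.8-fold lower number (0.27 log units; that floor lies within the scatter) from compound 3 to compound 4, at least 7.2-fold (0.85 log units) apart, beyond the scatter of two such steps

The reading for compound 3 is a limit of the assay and not a number: the limit of > 128000 nM in this assay, at which 1 of the 4 values shown sits.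

The step on the core of compound 3 is known only as a floor, its true size stays open, and two pairs neither explain the difference between the cores nor give a rule for any further core.

Still open, from the compounds shown here alone, is which part of the difference between the core of compound 1 and the core of compound 3 sets the direction of the step, and whether the hydrogen-bond donor counted for isopropylamino, absent from ethyl(methyl)amino, plays any part in it. Also open, going by these compounds, is how dimethylamino, tert-butylamino or a longer chain such as n-butylamino on the same carbonyl carbon would read on each of the two cores.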